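Anilide and benzylamide analogues of the shared core: a new ethoxy anilide

This account rests on a few compounds, and the source may have more. Where it says the series, first, only, none or still open, it means among the compounds named here.

Working notes on three measured amides of the shared core and one still open. Compound 1 `COc1ccc2c(=O)c(/C=C/C(=O)Nc3ccccc3)coc2c1` carries a methoxy-bearing core joined through the unsaturated amide to a plain phenyl. In a functional assay on L02 cells (Homo sapiens) for inhibition, read by MTT assay, with a stated time of 48 h (on this read-out lower numbers stand for stronger inhibition and higher numbers for weaker inhibition), compound 1 gives > 200000 nM, which is a limit of the assay and not a number. Compound 2 `O=C(/C=C/c1coc2cc(O)ccc2c1=O)NCc1ccccc1` and compound 3 `Cc1ccc(CNC(=O)/C=C/c2coc3cc(O)ccc3c2=O)cc1` are the corresponding benzylamides on the hydroxy-bearing core. In this assay compound 2 gives > 200000 nM, a limit. In this assay compound 3 gives > 200000 nM, also a limit. For the measured compounds named here, the single one-place step in the set, a step that the two limits leave unreadable from compound 2 to compound 3, therefore cannot be read. All the read-outs sit at the limit of > 200000 nM in this assay, at which 3 of the 3 values shown sit.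

Compound 4 `CCOc1ccc(NC(=O)/C=C/c2coc3cc(OC)ccc3c2=O)cc1` differs from compound 1 by ethoxy in place of hydrogen on an aromatic carbon. Going by the values given here, no measured step reaches this change; the only step in the set is unreadable. Compound 4 is therefore expected to stay at the limit as well, with no shift beyond the scatter, which would mean a step that the limit leaves unreadable from compound 1 to compound 4. The estimate for compound 4 is 250000 nM, with a range from 100000 nM to 800000 nM.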

Compound 4, half-maximal inhibitory concentration: > 200000 nM
Compound 4: only a limit was reported; the forecaster's own chance of this, stated with the estimate: 85%; the middle value lies beyond the limit too.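

Compound 4 gives > 200000 nM in this assay, which is a limit and not a number. Compound 1 also sits at a limit, so no new step can be read between compound 1 and compound 4: the limit of > 200000 nM in this assay, at which 4 of the 4 values shown sit. The compounds shown leave open whether any change on the shared core brings a measurable value in this read-out.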